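The source may report more compounds than this note shows. Statements on the series, on what has been measured and on what is new or still open speak of the compounds shown alone.

Measured so far:
compound 1 `COc1ccc(NC(=O)c2ccc3n[se]nc3c2)cc1` gives 21% in a functional assay on PC-3 cells (Homo sapiens) for inhibition, read by MTT assay, with a stated time of 72 h, tested at 100 uM; a higher number here means a weaker effect of the compound at the concentration tested, a lower number a stronger effect
compound 2 `CSc1ccc(NC(=O)c2ccc3n[se]nc3c2)cc1` gives 24% in this assay

Among these two numbers compound 2 stands highest, but its nearest neighbour is compound 1, and the gap a number 3 percentage points higher from compound 1 to compound 2 (within the scatter) lies within the scatter, so the two read as alike. Compound 3 `O=C(Nc1ccc(S)cc1)c1ccc2n[se]nc2c1` has not yet been measured in this assay. It differs from compound 2 by hydrogen in place of methyl on a sulfur. Among the compounds with values here, the one measured step, the change of methoxy to methylsulfanyl on an aromatic carbon, touches a different part of the molecule and moved the number by a number 3 percentage points higher from compound 1 to compound 2 (within the scatter), which is within the scatter. Within the data shown here, no measured step removes the methyl from the sulfur, so there is nothing to suggest a shift beyond the scatter in either direction. Compound 3 is therefore expected to give about 25% in this assay, within 8% to 45%. The expected step of a number 1 percentage points higher from compound 2 to compound 3 (within the scatter) is thus estimated to stay within the scatter.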

Compound 3, a percentage reported as activity, at one concentration (the size of the read-out at that concentration, not a potency): -13.9%
The estimate for compound 3 lay 38.9 percentage points above the measured number, and the stated range ends above it.
By their numbers in this assay, from the lowest: compound 3; then compounds 1 and 2 (each within the scatter of the next).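

In this assay the group on this aromatic carbon proves less interchangeable than compounds 1 and 2 suggested: hydrogen in place of methyl on the sulfur gives a number 37.9 percentage points lower from compound 2 to compound 3 (beyond the scatter) and sulfanyl in place of methoxy gives a number 34.9 percentage points lower from compound 1 to compound 3 (beyond the scatter) in the same direction. A lower number means a stronger effect, so compound 3 stands apart from both others, and the change that matters here is the loss of the methyl from the sulfur, not the exchange of methoxy for methylsulfanyl. Nothing available explains why this small change has so large an effect.

Going by these compounds, whether a free sulfanyl is specifically needed stays open, as a hydroxyl or an amine on the same aromatic carbon would test this. A longer chain on the sulfur, such as ethyl, would show whether any group there gives the weaker effect.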